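The source may report more compounds than this note shows. Statements on the series, on what has been measured and on what is new or still open speak of the compounds shown alone.

Compound 1: `CSc1nnc(-c2ccc(C)cc2)n1C` — > 100 mg/kg
Compound 2: `Cc1ccc(-c2nnc(S(C)(=O)=O)n2C)cc1` — > 200 mg/kg
Compound 3: `COc1ccc(-c2nnc(S(C)(=O)=O)n2C)cc1` — not yet measured

In a functional assay on the whole organism for antagonist activity, with Mus musculus as the target, in the maximal electroshock model (on this read-out higher numbers stand for an effect only at larger amounts of compound and lower numbers for an effect already at smaller amounts), compound 1 gives > 100 mg/kg, which is a limit of the assay rather than a measured number. Compound 2 gives > 200 mg/kg in this assay, again only a limit. These two compounds differ by methylsulfonyl in place of methylsulfanyl on an aromatic carbon, and the step that the two limits leave unreadable from compound 1 to compound 2 cannot be read because the limit of > 100 mg/kg in this assay, at which 1 of the 2 values shown sits, and the limit of > 200 mg/kg in this assay, at which 1 of the 2 values shown sits, are both limits. Compound 2 therefore stands at the upper edge of what this assay reports, with no numbered value beneath it.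

Compound 3 differs from compound 2 only on the six-membered aromatic ring of carbon: methoxy in place of methyl on an aromatic carbon. Among the compounds with values here, no measured step touches that ring, so nothing in the data tells how large an effect such a change produces in this assay. Starting from a compound whose value is itself a limit, compound 3 is expected to stay near that same edge, with an estimated step that the limit leaves unreadable from compound 2 to compound 3. The estimate for compound 3 in this assay is 250 mg/kg, expected to lie between 100 mg/kg and 600 mg/kg.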

Compound 3, dose for half-maximal effect: > 200 mg/kg
Compound 3: only a limit was reported; the forecaster's own chance of this, stated with the estimate: 70%; the middle value lies beyond the limit too.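

In this assay compound 3 gives > 200 mg/kg, which is a limit of the assay and not a number. Compound 2 also stands only at a limit, so the step between compound 2 and compound 3 cannot be read. The compounds shown leave open what size of effect, if any, methoxy in place of methyl produces in this assay.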